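Removing one fluoro group from compound 2

A few compounds are considered here, and "the series" means these few. Any claim that something is new, unique, unknown or untested is made for them only; others in the source may bear on it.

Values so far in a functional assay on NCI-H460 cells (Homo sapiens) for inhibition, with a stated time of 72 h (a higher number here means a weaker inhibitor, a lower number a stronger inhibitor), are as follows:
- compound 1 `COc1ccc(S(=O)(=O)N2CCc3cccc(-c4ccco4)c32)cc1` gives 94.5 nM
- compound 2 `COc1ccc(S(=O)(=O)N2CCc3cccc(-c4ccc(F)c(F)c4)c32)cc1` gives 46 nM

For the measured compounds named here, on these numbers, compound 2 stands lowest at 46 nM and compound 1 is the nearest at 94.5 nM in this assay so far.

The next comparison is with compound 3 `COc1ccc(S(=O)(=O)N2CCc3cccc(-c4ccc(F)cc4)c32)cc1` where hydrogen replaces fluoro on an aromatic carbon, ortho to a fluoro group and meta to a large group. The counted difference is hydrogen in place of fluoro on an aromatic carbon and the same change reads 3,4-difluorophenyl to 4-fluorophenyl.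

Going by the values given here, only one measured step bears on this, and only indirectly. It is a 2.1-fold lower number from compound 1 to compound 2 (0.31 log units; beyond the scatter) and it is modest. Among the compounds with values here, that step exchanges furan-2-yl for 3,4-difluorophenyl, so no measured pair isolates the loss of one fluoro group. A small move to a higher number is expected, possibly no larger than the scatter. The estimated change is a 1.3-fold higher number from compound 2 to compound 3 (0.12 log units; within the scatter) in this assay on this reading. Compound 3 is expected at about 60 nM with an estimated range from 25 nM to 140 nM in this assay.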

Compound 3, half-maximal inhibitory concentration: 95.5 nM
Compound 3: the middle estimate sits 1.6-fold (0.20 log units) below what was measured, and the stated range covers the measured number.
By their numbers in this assay, from the lowest: compound 2; then compounds 1 and 3 (each within the scatter of the next).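

In this assay, the fluoro group leaving the 3,4-difluorophenyl ring gives the first change isolated to a single atom on this ring, and the result is a 2.1-fold higher number from compound 2 to compound 3 (0.32 log units; beyond the scatter), so this one fluoro group, ortho to the other fluoro group and meta to the large group, carries a modest but readable share of the number. The 4-fluorophenyl and furan-2-yl groups are not separated in this assay (a 1.0-fold higher number from compound 1 to compound 3 (0.00 log units; within the scatter)), so among the compounds shown the advantage of compound 2 over both neighbours appears only with the 3,4-difluorophenyl group. No measured information accompanies these numbers to account for the step at this position.

An unsubstituted phenyl group would show what the remaining fluoro group contributes, and a 3-fluorophenyl group would show whether either fluoro group can stand alone. A chloro or methoxy group in place of the departing fluoro group, or an amine at the same carbon, would test whether the step belongs to fluoro itself or to any group at that place.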